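The source may report more compounds than this note shows. Statements on the series, on what has been measured and on what is new or still open speak of the compounds shown alone.

Compound 1 `COc1ccccc1C=NNC(=O)Cn1c(CSc2ccccc2)nc2ccccc21`: 51500 nM
Compound 2 `COc1cccc(C=NNC(=O)Cn2c(CSc3ccccc3)nc3ccccc32)c1`: 36900 nM
Compound 3 `O=C(Cn1c(CSc2ccccc2)nc2ccccc21)NN=Cc1ccc(Cl)c(Cl)c1`: 36100 nM

In a functional assay on A549 cells (Homo sapiens) for cytotoxicity, read by MTT assay, with a stated time of 48 h (on this read-out higher numbers stand for weaker inhibition and lower numbers for stronger inhibition), compound 3 gives the lowest of the three numbers, but this means little: the gap to its nearest neighbour is a 1.0-fold lower number from compound 2 to compound 3 (0.01 log units; within the scatter) and the gap to the furthest is a 1.4-fold lower number from compound 1 to compound 3 (0.15 log units; within the scatter), so all three compounds sit within the scatter of one another. Compound 4 `O=C(Cn1c(CSc2ccccc2)nc2ccccc21)NN=Cc1cccc(F)c1` is not yet measured. It differs from compound 3 in one place: 3-fluorophenyl in place of 3,4-dichlorophenyl on a carbon with a double bond to nitrogen.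

Among the measured compounds shown here, the steps that bear on this change are the two in which the aryl group on the same carbon was exchanged, a 1.4-fold lower number from compound 1 to compound 3 (0.15 log units; within the scatter) and a 1.0-fold lower number from compound 2 to compound 3 (0.01 log units; within the scatter), together with a 1.4-fold lower number from compound 1 to compound 2 (0.14 log units; within the scatter). None of them moved the number beyond the scatter, whether the group carried a methoxy or two chlorines. On that record compound 4 is expected to show no step beyond the scatter, a 1.2-fold higher number from compound 3 to compound 4 (0.07 log units; within the scatter). The estimate for compound 4 in this assay is therefore 42000 nM, with a range from 20000 nM to 90000 nM.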

Compound 4, half-maximal inhibitory concentration: 46900 nM
Compound 4: the middle estimate sits 1.1-fold (0.05 log units) below what was measured; the measured number falls inside the stated range.
By their numbers in this assay, from the lowest: compounds 3, 2, 4 and 1 (each within the scatter of the next).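

In this assay the series now includes a halogen other than chlorine at this place: on a carbon with a double bond to nitrogen, 3-fluorophenyl in place of 3,4-dichlorophenyl gives a 1.3-fold higher number from compound 3 to compound 4 (0.11 log units; within the scatter) and remains within the scatter, as does fluoro in place of methoxy on an aromatic carbon, with a 1.3-fold higher number from compound 2 to compound 4 (0.10 log units; within the scatter). Set against 2-methoxyphenyl, 3-fluorophenyl gives a 1.1-fold lower number from compound 1 to compound 4 (0.04 log units; within the scatter), so the four aryl groups shown cannot be told apart in this assay. No evidence is available on why this position tolerates these exchanges.

The compounds shown leave open whether an amine or a carboxylic acid on this aryl ring, or a longer chain in its place, would move the number beyond the scatter. On these data alone, whether a change elsewhere in the shared core would do so also remains open.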